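Swapping the oxadiazole on the benzyl ether of compound 2

The compounds below may be only part of what the source reports. "The series", "measured", "known", "first", "only" and "open" are said of these compounds alone.

Measured compounds:
compound 1, `COC(=O)C1=C(C)N=C(C)/C(=C(\O)OC)C1c1cccc([N+](=O)[O-])c1`, 1.2 nM
compound 2, `COC(=O)C1=C(C)N=C(C)/C(=C(/O)OC)C1c1ccccc1OCc1nonc1C`, 27 nM

Of the compounds shown here, two have been measured in an assay on Cortex for displacement of a labelled ligand from Voltage-dependent L-type calcium channel subunit alpha-1D (Rattus norvegicus); a lower number here means a stronger inhibitor, a higher number a weaker inhibitor. Compound 1 gives 1.2 nM. Compound 2 gives 27 nM, the higher of the two numbers, with compound 1 standing well beyond the scatter below it. The two structures differ in more than one place, so only their values can be compared, not a single change.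

Compound 3, `COC(=O)C1=C(C)N=C(C)/C(=C(/O)OC)C1c1ccccc1OCc1c(C#N)no[n+]1[O-]`, has not been measured. It differs from compound 2 at the saturated chain carbon bound to an oxygen on the aromatic ring, as a group of 8 heavy atoms (3 carbon, 3 nitrogen, 2 oxygen; one five-membered aromatic ring with 3 hetero atoms) in place of a group of 6 heavy atoms (3 carbon, 2 nitrogen, 1 oxygen; one five-membered aromatic ring with 3 hetero atoms), on a saturated chain carbon bound to an oxygen on an aromatic ring. Among the measured compounds shown here, no measured pair shows this change, so the size of the step is uncertain. The shared core and the rest of the molecule are kept. Compound 3 is expected to stay close to compound 2, with a step of a 1.5-fold higher number from compound 2 to compound 3 (0.17 log units; within the scatter), and its estimated value is 40 nM, between 10 nM and 160 nM.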

Compound 3, inhibition constant: 30 nM
For compound 3 the middle estimate is 1.3-fold (0.12 log units) above the measured one; measured number inside the range.
By their numbers in this assay, from the lowest: compound 1; then compounds 2 and 3 (each within the scatter of the next).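

In this assay, the one change shown at the saturated chain carbon bound to an oxygen on an aromatic ring gives a 1.1-fold higher number from compound 2 to compound 3 (0.05 log units; within the scatter), so compound 2 and compound 3 cannot be told apart. This place therefore accepts the entering group, with its larger count of heavy atoms, its triple bond outside aromatic rings and its extra hydrogen-bond acceptor, in place of 4-methyl-1,2,5-oxadiazol-3-yl without a separation in the read-out, although this rests on a single pair. Nothing shown here offers an explanation for this result.

Going by these compounds, it remains open whether a group with no five-membered aromatic ring at this place, such as a simple amine or a carboxylic acid, would also stay within the scatter. Compound 1 differs from both compounds in more than one place, so which structural difference accounts for its separation also remains unresolved.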